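Cytotoxicity working notes on compounds 1 to 4

This account rests on a few compounds, and the source may have more. Where it says the series, first, only, none or still open, it means among the compounds named here.

Measured so far in an ADME assay on HEL cells (Homo sapiens) for cytotoxicity, with a stated time of 3 days; on this read-out lower numbers stand for higher toxicity in this test and higher numbers for lower toxicity in this test:
compound 1 `Cc1cc(-n2ccc3ccccc32)cn2c(CSCCc3ccccc3)cnc12`, 18 ug/mL
compound 2 `Cc1cc(Sc2ccc(O)cc2)cn2c(CSCCc3ccccc3)cnc12`, 100 ug/mL
compound 3 `Cc1cc(N2CCCC2=O)c2ncc(CSCCc3ccccc3)n2c1`, 25 ug/mL

Compound 3 stands second highest of the three numbers; compound 1 sits within the scatter of it, compound 2 lies beyond the scatter above it. Compound 4 `Cc1cc(-n2ccc3cccnc32)c2ncc(CSCCc3ccccc3)n2c1` differs from compound 3 by a group of 9 heavy atoms (7 carbon, 2 nitrogen; one five-membered aromatic ring with 1 hetero atom, one six-membered aromatic ring with 1 hetero atom) in place of a group of 6 heavy atoms (4 carbon, 1 nitrogen, 1 oxygen; one five-membered non-aromatic ring with 1 hetero atom), on an aromatic carbon. Going by the values given here, the only measured step, a 5.6-fold higher number from compound 1 to compound 2 (0.74 log units; beyond the scatter), concerns a different exchange at the same place and is only loosely related. Compound 1 carries a related bicyclic group at that position and gives 18 ug/mL, close to compound 3, so a step of a 1.3-fold lower number from compound 3 to compound 4 (0.10 log units; within the scatter) is expected, within the scatter. Compound 4 is thus estimated at 20 ug/mL, range 8 ug/mL to 50 ug/mL.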

Compound 4, half-maximal cytotoxic concentration: > 100 ug/mL
Compound 4 was reported as a limit; the forecaster's own chance of this, stated with the estimate: 5%; at least 5.0-fold (0.69 log units) between middle value and limit.
By their numbers in this assay, from the lowest: compounds 1 and 3 (each within the scatter of the next); then compound 2.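

The exchange at this aromatic carbon, two atoms from the ring nitrogen, gives in this assay an at least 4.0-fold higher number from compound 3 to compound 4 (0.60 log units; beyond the scatter), the first step read at this place, and it lies beyond the scatter. The change adds a second aromatic ring system in place of 2-oxopyrrolidin-1-yl, and the number moves upward. Compound 4 gives a limit of the assay, not a number, so the full size of the step stays open: the limit of > 100 ug/mL in this assay, at which 1 of the 4 values shown sits.

From the compounds shown here alone, whether a simple amine or a carboxylic acid at this carbon would keep the number this high remains open. The compounds shown also leave open whether 1H-indol-1-yl here would behave like the group in compound 4.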